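Extending the cap of a hydroxamic acid benzimidazole series

The compounds below may be only part of what the source reports. "The series", "measured", "known", "first", "only" and "open" are said of these compounds alone.

Measured compounds:
- compound 1 `O=C(CCCCCCc1nc2ccc(F)cc2[nH]1)NO`: 1900 nM
- compound 2 `O=C(CCCCCCc1nc2ccc(Cl)cc2[nH]1)NO`: 320 nM

In a functional assay on SK-OV-3 cells (Homo sapiens) for cytotoxicity (a lower number here means a stronger inhibitor, a higher number a weaker inhibitor), compound 1 gives the highest of the two numbers; its nearest neighbour is compound 2, reached by a 5.9-fold lower number from compound 1 to compound 2 (0.77 log units; beyond the scatter). Among the measured compounds shown here, that single step, chloro in place of fluoro on an aromatic carbon, is the only measured change in the set.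

Compound 3 `COc1ccc(-c2ccc3nc(CCCCCCC(=O)NO)[nH]c3c2)cc1` carries a larger replacement on the same carbon: 4-methoxyphenyl in place of fluoro on an aromatic carbon. The change shares with the step from compound 1 to compound 2 the position on the shared core and the departure of fluoro, but what enters is a whole aromatic ring rather than another halogen, so the measured step bears on it only loosely. It shows that this position tolerates a different group without loss in this assay, and that the modest gain there went in the direction of a lower number.

Compound 3 is therefore expected to give a lower number than compound 1 in this assay, by about a 3.8-fold lower number from compound 1 to compound 3 (0.58 log units; beyond the scatter), with considerable uncertainty. The estimate for compound 3 is 500 nM, within a range from 150 nM to 1800 nM.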

Compound 3, half-maximal inhibitory concentration: 3100 nM
The estimate for compound 3 lay 6.2-fold (0.79 log units) below the measured number; measured number outside the range, above it.
By their numbers in this assay, from the lowest: compound 2; then compounds 1 and 3 (each within the scatter of the next).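

In this assay the lower number seen with chloro does not extend to the larger group: 4-methoxyphenyl in place of fluoro gives a 1.6-fold higher number from compound 1 to compound 3 (0.21 log units; within the scatter), whereas 4-methoxyphenyl in place of chloro gives a 9.7-fold higher number from compound 2 to compound 3 (0.99 log units; beyond the scatter). This aromatic carbon therefore accepts a whole aromatic ring with a number that cannot be told apart from that of the fluoro compound, and among the three compounds only the chloro compound stands apart, with a number lower than both of the others. Nothing in the data shown accounts for why chloro differs from the other two groups.

The compounds shown leave open whether the number at this carbon follows the added ring or its methoxy group, a question that a plain phenyl or a 4-hydroxyphenyl group would address, and whether bromo, methyl or an amine at the same carbon would match chloro. They also leave open whether the same ordering of these groups would hold with a longer chain leading to the hydroxamic acid.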